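The source may report more compounds than this note shows. Statements on the series, on what has been measured and on what is new or still open speak of the compounds shown alone.

Measured in a functional assay on the whole organism (strain albino) for inhibition, with Rattus norvegicus as the target, read by paw edema, with stated times of 30 min and 5 h, at a dose of 100 mg/kg by the oral route; a lower number here means less inhibition, a higher number more inhibition at the dose given (going by the name of the read-out):
Compound 1, `O=C(CO[N+](=O)[O-])Nc1ccc(C(=O)/C=C/c2ccc(Cl)cc2)cc1`, gives 60%.
Compound 2, `O=C(CO[N+](=O)[O-])Nc1ccc(C(=O)/C=C/c2ccco2)cc1`, gives 39%.
Compound 3, `CC(Br)C(=O)Nc1ccc(C(=O)/C=C/c2ccc(Cl)cc2)cc1`, gives 50%.

Among these three numbers compound 1 stands highest. Compound 3 lies nearest to it, with a number 10 percentage points lower from compound 1 to compound 3 (within the scatter), and compound 2 lies furthest, with a number 21 percentage points lower from compound 1 to compound 2 (beyond the scatter).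

The compound not yet measured is compound 4, `C/C(=N/O)c1ccc(OCC(=O)Nc2ccc(C(=O)/C=C/c3ccc(Cl)cc3)cc2)cc1`. Compared with compound 1 the change is this: a group of 10 heavy atoms (8 carbon, 1 nitrogen, 1 oxygen; one six-membered aromatic ring of carbon only) in place of a group of 3 heavy atoms (1 nitrogen, 2 oxygen; no ring), on an oxygen on a saturated carbon. It sits on the acyl side of the shared core, away from the double-bonded chain and the aryl group at its end.

Among the measured compounds shown here, of the two measured steps, the one from compound 1 to compound 3 bears on this change, since it also altered the group on the carbonyl carbon of the amide; it gave a number 10 percentage points lower from compound 1 to compound 3 (within the scatter). The step from compound 1 to compound 2 changed the aryl group on the double-bonded chain instead and gave a number 21 percentage points lower from compound 1 to compound 2 (beyond the scatter); it speaks to a different part of the molecule. For the measured compounds named here, the present change is far larger in size than the one seen in compound 3, and nothing measured shows how an entering group of this size on the acyl side behaves, so the expectation is uncertain. Because a number 10 percentage points lower from compound 1 to compound 3 (within the scatter) stayed within the scatter, compound 4 is expected to remain near compound 1, with some allowance for a downward drift. The estimated step is a number 8 percentage points lower from compound 1 to compound 4 (within the scatter). Compound 4 is therefore expected to give 52%, within a range of 30% to 72%.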

Compound 4, a percentage reported as inhibition, in the whole organism at one dose (the size of the read-out at that dose, not a potency): 49%
Compound 4: middle estimate off by 3 percentage points, on the high side, within the range that was stated.
By their numbers in this assay, from the lowest: compounds 2, 4, 3 and 1 (each within the scatter of the next, the first and the last beyond it).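

In this assay the large group on the oxygen on a saturated carbon gives a number 11 percentage points lower from compound 1 to compound 4 (beyond the scatter), so this position accepts a far larger group carrying a six-membered aromatic ring, and the inhibition does not disappear when the nitro group leaves. The earlier change on this side of the molecule, in compound 3, stayed within the scatter, whereas this one lies just beyond it; even so, compound 4 gives 49% and compound 3 gives 50%, two values within the scatter of each other, so neither replacement of the nitrooxy end stands apart from the other. Nothing at hand accounts for the step.

The entering group differs from the nitro group in size, ring and atoms all at once, so compound 4 alone cannot show which of these features goes with the step, and a simple methyl or an unsubstituted phenyl on the same oxygen would help to separate them. As far as these compounds go, it also remains open whether furan-2-yl in place of 4-chlorophenyl would give a similar step when this large group is present.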